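Shortening the perfluoroalkyl chain on a triazole-linked nucleoside

The source may report more compounds than this note shows. Statements on the series, on what has been measured and on what is new or still open speak of the compounds shown alone.

Measured compounds:
Compound 1 `CC(=O)OC[C@H]1O[C@@H](n2cc(-c3cn(CCC(F)(F)C(F)(F)C(F)(F)C(F)(F)C(F)(F)C(F)(F)C(F)(F)C(F)(F)F)nn3)c(=O)[nH]c2=O)C[C@@H]1OC(C)=O` — 99.1 uM
Compound 2 `O=c1[nH]c(=O)n([C@H]2C[C@H](O)[C@@H](CO)O2)cc1-c1cn(CCC(F)(F)C(F)(F)C(F)(F)C(F)(F)F)nn1` — 110 uM
Compound 3 `O=c1[nH]c(=O)n([C@H]2C[C@H](O)[C@@H](CO)O2)cc1-c1cn(CCC(F)(F)C(F)(F)C(F)(F)C(F)(F)C(F)(F)C(F)(F)F)nn1` — 107 uM

In a functional assay on MDA-MB-231 cells (Homo sapiens) for antiproliferative activity, read by sulforhodamine B assay (on this read-out lower numbers stand for stronger inhibition of growth and higher numbers for weaker inhibition of growth), compound 2 gives 110 uM, the highest of the three numbers, though its neighbours sit close: compound 3 at 107 uM and compound 1 at 99.1 uM are both within the scatter of it. Compound 4 `O=c1[nH]c(=O)n([C@H]2C[C@H](O)[C@@H](CO)O2)cc1-c1cn(CCC(F)(F)C(F)(F)F)nn1` has not been measured. It differs from compound 2 in one place: fluoro in place of 1,1,2,2,2-pentafluoroethyl on a saturated chain carbon bound to two fluorine atoms and a saturated chain carbon. Among the measured compounds shown here, the only measured step that bears on this change is the one running the other way, from compound 2 to compound 3, where the chain grew by a 1,1,2,2,2-pentafluoroethyl and the number moved by a 1.0-fold lower number from compound 2 to compound 3 (0.01 log units; within the scatter). Lengthening the chain left the read-out essentially unchanged, so shortening it is expected to do the same, with no step beyond the scatter in either direction. The expected step is a 1.0-fold lower number from compound 2 to compound 4 (0.02 log units; within the scatter). Compound 4 is therefore estimated at 105 uM, in a range from 55 uM to 200 uM.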

Compound 4, concentration for growth inhibition (reported as GI): 98.7 uM
Estimate against measurement, compound 4: 1.1-fold (0.03 log units) above; measured number inside the range.
By their numbers in this assay, from the lowest: compounds 4, 1, 3 and 2 (each within the scatter of the next).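

In this assay, removing the 1,1,2,2,2-pentafluoroethyl in favour of fluoro gives a 1.1-fold lower number from compound 2 to compound 4 (0.05 log units; within the scatter). Together with a 1.0-fold lower number from compound 2 to compound 3 (0.01 log units; within the scatter), this means the chain has now been varied in both directions from compound 2, and neither the shorter nor the longer chain gives a step beyond the scatter. Nothing available explains why the read-out stays flat across these chains.

The compounds shown leave open whether a plain hydrocarbon chain with no fluorine, or an amine or carboxylic acid at the end of the chain, would move the number beyond the scatter. They also leave open what the two acetate esters of compound 1 contribute alone, since that compound differs from the others in its chain as well.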